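The source may report more compounds than this note shows. Statements on the series, on what has been measured and on what is new or still open speak of the compounds shown alone.

Three compounds of the series have entries so far in an ADME assay on MRC5 cells (Homo sapiens) for cytotoxicity, read by fluorescence and resazurin assay, with a stated time of 3 days (on this read-out lower numbers stand for stronger inhibition and higher numbers for weaker inhibition), on the shared core. Compound 1 (`Cc1cn(C2CCN(Cc3cncc(Oc4cccc(Cl)c4)c3)CC2)c(=O)[nH]c1=O`) gives > 64000 nM as a limit of the assay and not a number. Compound 2 (`Cc1cn(C2CCN(Cc3cccc(Oc4cccc(F)c4)c3)CC2)c(=O)[nH]c1=O`) gives > 64000 nM as a limit of the assay and not a number. Compound 3 (`Cc1cn(C2CCN(Cc3cccc(Oc4ccc(O)cc4)n3)CC2)c(=O)[nH]c1=O`) is recorded as "not determined" (no result reported) and so adds no result. Compound 2 therefore stands on the limit of > 64000 nM in this assay, at which 2 of the 3 values shown sit, and has no number of its own.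

Compound 4 (`Cc1cn(C2CCN(Cc3cccc(Oc4cc(F)cc(F)c4)c3)CC2)c(=O)[nH]c1=O`) differs from compound 2 in one place, by fluoro in place of hydrogen on an aromatic carbon on the outer ring: 3-fluorophenoxy becomes 3,5-difluorophenoxy, fluoro in place of hydrogen on an aromatic carbon, meta to a fluoro group.

Among the compounds with values here, no step between measured compounds exists, so this change has no direct precedent. In this assay no change beyond the usual scatter is expected and no direction is favoured, with compound 2 at the limit > 64000 nM as the only anchor. The expected step of a number no higher from compound 2 to compound 4 (the limit leaves the size open) is estimated to stay within the scatter. For compound 4 the estimate is 64000 nM with an expected range from 30000 nM to 100000 nM and a report of only a limit is the likely outcome.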

Compound 4, half-maximal inhibitory concentration: > 64000 nM
Compound 4: no number, only a limit; the forecaster's own chance of this, stated with the estimate: 85%; the middle value lies on the limit itself.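

In this assay, within the data shown here, compound 2 and compound 4 each give only a limit of the assay and not a number, and no step between them can be read. The compounds shown leave open whether fluoro in place of hydrogen on an aromatic carbon alters the half-maximal inhibitory concentration in this assay, and where any compound's actual value lies.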